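The source may report more compounds than this note shows. Statements on the series, on what has been measured and on what is new or still open speak of the compounds shown alone.

Measured in a functional assay on MCF7 cells (Homo sapiens) for antiproliferative activity, read by MTT assay, with a stated time of 72 h; on this read-out lower numbers stand for stronger inhibition and higher numbers for weaker inhibition:
- Compound 1 (`CCCCCCCCNC[C@@H]1OC[C@H](N)[C@@H]1O`) gives 96600 nM
- Compound 2 (`CCCCCCCCNC[C@@H]1OC[C@H](N)[C@H]1O`) gives > 128000 nM (a limit, not a number)

Among the measured compounds shown here, compound 1 holds the only actual number so far. Compound 3 (`CCCCCCCCCNC[C@@H]1OC[C@H](N)[C@@H]1O`) keeps the core of compound 1 and adds one change on the chain (methyl in place of hydrogen on a saturated chain carbon, eight bonds along the chain from an amine nitrogen). For the measured compounds named here, the sole measured step (an at least 1.3-fold higher number from compound 1 to compound 2 (0.12 log units; that floor lies within the scatter)) concerns configuration only (the fact that compounds 1 and 2 differ only in the configuration as drawn), so it sets no size for a chain change. Going by the values given here, with no measured chain step, no shift beyond the scatter is expected in this assay for compound 3. An expected step of a 1.2-fold lower number from compound 1 to compound 3 (0.08 log units; within the scatter) stays within the scatter. Compound 3 is estimated at 80000 nM (30000 nM to 160000 nM).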

Compound 3, half-maximal inhibitory concentration: 12500 nM
Compound 3: the middle estimate sits 6.4-fold (0.81 log units) above what was measured; measured number outside the range, below it.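

In this assay, methyl in place of hydrogen on a saturated chain carbon, eight bonds along the chain from an amine nitrogen, gives a 7.7-fold lower number from compound 1 to compound 3 (0.89 log units; beyond the scatter). This is the only chain step shown, and it makes this position sensitive: one added carbon moves the number beyond the scatter, towards stronger inhibition. Nothing available explains the size of this step.

As far as these compounds go, whether a longer chain, or a hydroxyl in place of the added methyl, would move the number further remains open. A single step defines no trend with chain length.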